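Removing One Methoxy from a Trimethoxyphenyl Pyrazole Chalcone

This account rests on a few compounds, and the source may have more. Where it says the series, first, only, none or still open, it means among the compounds named here.

Measured so far:
- compound 1, `COc1cc(-c2cc(/C=C/C(=O)c3ccc(N)cc3)[nH]n2)cc(OC)c1OC`: 99%
- compound 2, `COc1ccc(-c2cc(/C=C/C(=O)c3ccc(OC)c(OC)c3)[nH]n2)cc1`: 99%
- compound 3, `COc1cc(-c2cc(/C=C/C(=O)c3ccc(Cl)c(Cl)c3)[nH]n2)cc(OC)c1OC`: 97%

In a functional assay on UACC-62 cells (Homo sapiens) for cytotoxicity, read by sulforhodamine B assay, with a stated time of 48 h, tested at 0.01 uM (on this read-out higher numbers stand for a weaker effect at the one concentration tested and lower numbers for a stronger effect), compound 1 gives 99%, which is level with compound 2 at the digits shown and together the highest of the three numbers; compound 3 lies a number 2 percentage points lower from compound 1 to compound 3 (within the scatter).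

Compound 4, `COc1ccc(-c2cc(/C=C/C(=O)c3ccc(N)cc3)[nH]n2)cc1OC`, differs from compound 1 by hydrogen in place of methoxy on an aromatic carbon. Within the data shown here, no measured step changes a methoxy group, so none bears directly on this change. Among the measured compounds shown here, the only step available, 3,4-dichlorophenyl in place of 4-aminophenyl, was a number 2 percentage points lower from compound 1 to compound 3 (within the scatter), and compound 2, which also carries fewer methoxy groups, gives 99%. The expected step is therefore a number 1 percentage points lower from compound 1 to compound 4 (within the scatter), none beyond the scatter. Compound 4 is estimated at 98%, within 90% to 103%.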

Compound 4, a percentage reported as activity, at one concentration (the size of the read-out at that concentration, not a potency): 99%
The estimate for compound 4 lay 1 percentage points below the measured number, within the range that was stated.
By their numbers in this assay, from the lowest: compounds 3, 1, 2 and 4 (each within the scatter of the next).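

In this assay, among these compounds, hydrogen in place of methoxy on an aromatic carbon gives no change at the digits printed from compound 1 to compound 4 (within the scatter) and provides the first direct reading of a change at this position. With the 4-aminophenyl group kept on the carbonyl carbon, this methoxy can therefore be removed without moving the number beyond the scatter at the one concentration tested. No available evidence explains this result.

From the compounds shown here alone, whether a hydroxyl, a fluorine or an ethoxy group at this position would behave alike remains open. So does whether the same removal would leave the number unchanged with 3,4-dichlorophenyl on the carbonyl carbon.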